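The source may hold more compounds than are shown below. What is called first, only, known or untested is meant among the compounds shown, and "the series" means these compounds.

Compound 1 `Nc1ccc(C(=O)/C=C/c2ccc(O)c(F)c2)cc1-c1ccc(F)cc1` was tested in an assay on A549 cells for inhibition of transcription factor p65 (Homo sapiens), read by fluorescence, with a stated time of 2 h; a higher number here means a weaker inhibitor, a lower number a stronger inhibitor. In this assay compound 1 gives only a limit, > 50000 nM, and no number. Two further compounds with a different substitution pattern on the shared core were measured alongside it. Compound 2 `COc1ccc(/C=C/C(=O)c2cccc(-c3cccc(F)c3)c2)cc1OC` gives 33400 nM in this assay, and compound 3 `COc1ccccc1/C=C/C(=O)c1cccc(-c2cccc(F)c2)c1` gives 35300 nM; these two values lie within the usual scatter of each other, so neither can be called stronger than the other. All three compounds are weak inhibitors here.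

Compound 4 `COc1cc(/C=C/C(=O)c2ccc(N)c(-c3ccc(F)cc3)c2)ccc1O` has not yet been measured. It differs from compound 1 in a single place: methoxy in place of fluoro on an aromatic carbon. The fluoro leaves a carbon of the six-membered aromatic ring that sits ortho to a hydroxy group and meta to a large group, and a methoxy enters there, so that the 3-fluoro-4-hydroxyphenyl becomes a 4-hydroxy-3-methoxyphenyl.

For the measured compounds named here, no step between two measured compounds is available to guide the expectation. Compound 1 sits at the limit (the limit of > 50000 nM in this assay, at which 1 of the 3 values shown sits), and compounds 2 and 3 are weak as well. The expected step of an at least 1.1-fold lower number from compound 1 to compound 4 (0.04 log units; that floor lies within the scatter) is one of no change beyond the scatter. Compound 4 is expected to give about 45000 nM in this assay, with a range from 15000 nM to 150000 nM, and a limit rather than a number is quite possible.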

Compound 4, half-maximal inhibitory concentration: 6830 nM
Beside the measured number, compound 4's estimate is 6.6-fold (0.82 log units) above it; measured number below the stated range.
By their numbers in this assay, from the lowest: compound 4; then compounds 2 and 3 (each within the scatter of the next). At a limit, above all of these: compound 1.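

In this assay, for the compounds shown here, the exchange of 3-fluoro-4-hydroxyphenyl for 4-hydroxy-3-methoxyphenyl gives an at least 7.3-fold lower number from compound 1 to compound 4 (0.86 log units; beyond the scatter), so this ring position, ortho to a hydroxy group, can move the read-out beyond the scatter, something the earlier compounds, with no pair differing in one place, could not show. That step is only a floor and its full size stays unknown, as compound 1 gives a limit and not a number: the limit of > 50000 nM in this assay, at which 1 of the 4 values shown sits. Only this one place differs between the two compounds, so the gain goes with the exchange of fluoro for methoxy, though nothing here tells which feature of the methoxy group lies behind it.

As far as these compounds go, it remains open whether the gain needs a methoxy group at all, or whether a plain hydrogen, an ethoxy group or an amine on the same carbon would give a similar number. It also remains open whether the same exchange would help on other substitution patterns of the shared core, as the compounds shown hold it in a single pair.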